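The compounds below may be only part of what the source reports. "The series", "measured", "known", "first", "only" and "open" are said of these compounds alone.

Three compounds share one core and differ only in the chain that carries the amide and the pyridyl group. Compound 3 `Nc1nc2[nH]c(CCSCCC(=O)NCc3cccnc3)cc2c(=O)[nH]1` in a functional assay on KB cells (Homo sapiens) for antiproliferative activity, read by MTT assay, with a stated time of 72 h, in the presence of a further agent that is not named here (a lower number here means a stronger inhibitor, a higher number a weaker inhibitor), gives 648 nM. Compound 1 `Nc1nc2[nH]c(CCSCCC(=O)NCc3ccccn3)cc2c(=O)[nH]1` keeps the same chain length but carries the other pyridyl isomer; in this assay compound 1 gives 8930 nM. The change between them is pyridin-2-yl in place of pyridin-3-yl on a saturated chain carbon bound to an amide-type nitrogen, and it brought a 14-fold higher number from compound 3 to compound 1 (1.14 log units; beyond the scatter). Compound 2 `Nc1nc2[nH]c(CCSCC(=O)NCc3cccnc3)cc2c(=O)[nH]1` has a shorter chain between the sulfur and the amide; in this assay compound 2 gives 37500 nM. Compound 2 and compound 1 are not linked by a single counted step, so only their values can be compared, and compound 2 carries the highest number of the three. The difference between the cores of compound 2 and compound 3 is not broken down here.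

Compound 4 `Nc1nc2[nH]c(CCSCC(=O)NCc3ccccn3)cc2c(=O)[nH]1` is yet to be measured. Its relation to compound 2 is pyridin-2-yl in place of pyridin-3-yl on a saturated chain carbon bound to an amide-type nitrogen, the same change, at the same place, that leads from compound 3 to compound 1. Because that earlier change produced a 14-fold higher number from compound 3 to compound 1 (1.14 log units; beyond the scatter), the step from compound 2 to compound 4 is expected to be of similar size, roughly an 8.0-fold higher number from compound 2 to compound 4 (0.90 log units; beyond the scatter), though it rests on a single precedent. Compound 4 is therefore expected to give about 300000 nM in this assay, with a likely range from 80000 nM to 1000000 nM.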

Compound 4, half-maximal inhibitory concentration: 28400 nM
Estimate against measurement, compound 4: 11-fold (1.02 log units) above; measured number outside the range, below it.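

In this assay, placing pyridin-2-yl in place of pyridin-3-yl on a saturated chain carbon bound to an amide-type nitrogen gave a 1.3-fold lower number from compound 2 to compound 4 (0.12 log units; within the scatter), so on the core of compound 2 the change has no effect that can be told from the usual scatter. The large step seen on the core of compound 3 therefore did not carry over to the core of compound 2, and the size of this change depends on the core it is made on: the same change on two cores in this assay, a 14-fold higher number (1.14 log units; beyond the scatter) from compound 3 to compound 1 and a 1.3-fold lower number (0.12 log units; within the scatter) from compound 2 to compound 4, 18-fold (1.26 log units) apart, beyond the scatter of two such steps. Going by these compounds alone, this does not show which feature of the two cores accounts for the gap, nor does it give a rule for any further core, as each core offers only a single pair of pyridyl isomers, and the difference between the cores of compound 2 and compound 3 has not been broken down.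

The compounds shown leave open how a pyridin-4-yl group or a plain phenyl ring would behave in the same place on either core. They also leave open whether a chain longer than that of compound 3 would keep the pyridin-3-yl group ahead of the pyridin-2-yl group, or lose the difference again.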